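Swapping a Cyclohexyl Ring for a Dibromo-Alkenyl Chain

A few compounds are considered here, and "the series" means these few. Any claim that something is new, unique, unknown or untested is made for them only; others in the source may bear on it.

Compound 1: `CCC(C)[C@H]1O[C@@H](C)CC(Cl)=C1[Si](C)(C)C` — > 100000 nM in a functional assay on WiDr cells (Homo sapiens) for antiproliferative activity; on this read-out lower numbers stand for stronger inhibition of growth and higher numbers for weaker inhibition of growth
Compound 2: `C[C@H]1CC(Cl)=C([Si](C)(C)C)[C@@H](C2CCCCC2)O1` — 15000 nM
Compound 3: `C[C@@H]1O[C@H](C2CCCCC2)C([Si](C)(C)C)=C(Cl)[C@H]1C` — 42000 nM

Of the compounds shown here, three sharing one core have been tested. Compound 1 reaches only a limit of this assay, (the limit of > 100000 nM in this assay, at which 1 of the 3 values shown sits), so it gives no number. Compound 2 gives 15000 nM. Compound 3 gives 42000 nM, the highest of the two numbers shown, with compound 2 as its nearest neighbour.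

The two measured steps are an at least 6.6-fold lower number from compound 1 to compound 2 (0.82 log units; beyond the scatter) and a 2.8-fold higher number from compound 2 to compound 3 (0.45 log units; beyond the scatter). The first is the one that speaks to the next change, since it alters the same saturated ring carbon: moving from sec-butyl, a group with no ring, to cyclohexyl brought a clear drop in the number.

Compound 4, `C[C@@H]1O[C@H](CCC=C(Br)Br)C([Si](C)(C)C)=C(Cl)[C@H]1C`, carries the change (4,4-dibromobut-3-en-1-yl in place of cyclohexyl on a saturated ring carbon). Cyclohexyl leaves and a chain with no ring enters. Judged against the step from compound 1 to compound 2, compound 4 is expected to show a 1.7-fold higher number from compound 3 to compound 4 (0.22 log units; within the scatter), a higher number than compound 3. The estimate for compound 4 in this assay is 70000 nM, within 20000 nM to 250000 nM, with a real chance that only a limit is reported.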

Compound 4, concentration for 50% growth inhibition: 25000 nM
For compound 4 the middle estimate is 2.8-fold (0.45 log units) above the measured one, within the range that was stated.
By their numbers in this assay, from the lowest: compounds 2, 4 and 3 (each within the scatter of the next, the first and the last beyond it). At a limit, above all of these: compound 1.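

Putting the open chain in place of the ring gives a 1.7-fold lower number from compound 3 to compound 4 (0.23 log units; within the scatter), so in this assay these two groups cannot be told apart. The earlier step from sec-butyl to cyclohexyl, taken alone and on a core lacking the second ring methyl, could suggest that this saturated ring carbon needs a ring, but compound 4 shows that, with this second methyl present, a ring is not required to keep the reading of compound 3. Nothing in the data at hand explains why a ring and a dibrominated chain with the same count of heavy atoms read alike.

Still open, on these data alone, is which part of the chain matters, the two bromines or the double bond, and a plain butyl chain would separate these from chain length alone. Also open, as far as these compounds go, is how this carbon responds to a group of a different kind, such as an amine or a carboxylic acid.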